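Aryl substituent changes on the shared core: compound 4

The source may hold more compounds than are shown below. What is called first, only, known or untested is meant among the compounds shown, and "the series" means these compounds.

Measured in a functional assay on KB cells (Homo sapiens) for antiproliferative activity, read by sulforhodamine B assay, with a stated time of 3 days; on this read-out higher numbers stand for an effect only at larger amounts of compound and lower numbers for an effect already at smaller amounts:
compound 1 `CCC1=C(O)c2c(oc(-c3ccccc3)cc2=O)C(CC)(CC)C1=O`: > 236 uM (a limit of the assay)
compound 2 `CCC1=C(O)c2c(oc(-c3ccc(CC)cc3)cc2=O)C(CC)(CC)C1=O`: 21.9 uM
compound 3 `CCC1=C(O)c2c(oc(-c3ccccc3C(F)(F)F)cc2=O)C(CC)(CC)C1=O`: 45.6 uM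
compound 4 `CCC1=C(O)c2c(oc(-c3ccccc3OC)cc2=O)C(CC)(CC)C1=O`: not yet measured

Compound 1 gives only a limit in this assay, > 236 uM, as noted in the limit of > 236 uM in this assay, at which 1 of the 3 values shown sits. Among the two real numbers, compound 2 stands lowest with 21.9 uM; compound 3 gives 45.6 uM, a gap beyond the scatter.

The step to compound 4 is 2-methoxyphenyl in place of 4-ethylphenyl on an aromatic carbon. For the measured compounds named here, two measured steps bear on it: an at least 10-fold lower number from compound 1 to compound 2 (1.03 log units; beyond the scatter), and an at least 5.1-fold lower number from compound 1 to compound 3 (0.71 log units; beyond the scatter). Both show that a substituted phenyl on the shared core brings the number down from the limit of compound 1, with the 4-ethylphenyl of compound 2 giving the lower number and the trifluoromethyl-bearing phenyl of compound 3 a somewhat higher one.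

For compound 4, exchanging 4-ethylphenyl for 2-methoxyphenyl is therefore expected to give a moderate rise, a 2.3-fold higher number from compound 2 to compound 4 (0.36 log units; beyond the scatter). Compound 4 is estimated at 50 uM, within 15 uM to 170 uM.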

Compound 4, concentration for half-maximal effect: 40.8 uM
Beside the measured number, compound 4's estimate is 1.2-fold (0.09 log units) above it; the measured number falls inside the stated range.
By their numbers in this assay, from the lowest: compounds 2, 4 and 3 (each within the scatter of the next, the first and the last beyond it). At a limit, above all of these: compound 1.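

In this assay, 2-methoxyphenyl does not separate from either neighbouring compound: a 1.9-fold higher number from compound 2 to compound 4 (0.27 log units; within the scatter), and a 1.1-fold lower number from compound 3 to compound 4 (0.05 log units; within the scatter). Methoxy thus joins ethyl and trifluoromethyl as a third substituent on the phenyl whose compound gives a real number rather than a limit, with an at least 5.7-fold lower number from compound 1 to compound 4 (0.76 log units; beyond the scatter). Compound 1 stands at a limit, so every step from it gives only a bound on its size: the limit of > 236 uM in this assay, at which 1 of the 4 values shown sits.

Going by these compounds, the size of the gain from substituting the phenyl stays open, as does whether methoxy would give the same number at another place on that ring. Also open, on these data alone, is what an amine or a carboxylic acid on the phenyl would give in this assay.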